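Piperazine variants on the aromatic carbon of the core

The source may report more compounds than this note shows. Statements on the series, on what has been measured and on what is new or still open speak of the compounds shown alone.

Compound 2, `CN(C[C@H]1Cc2c(cccc2N2CCNC(C)(C)C2)CN1)[C@H]1CCCc2cccnc21`: 33.9 nM
Compound 1, `CN(C[C@H]1Cc2c(cccc2N2CCN(C3COC3)CC2)CN1)[C@H]1CCCc2cccnc21`: 381 nM

Within the data shown here, in a functional assay on CCRF-CEM cells for antagonist activity at C-X-C chemokine receptor type 4 (Homo sapiens), read by calcium flux, with stated times of 25 min and 90 s (a lower number here means a stronger inhibitor, a higher number a weaker inhibitor), compound 2 gives the lowest of the two numbers; the single measured step, an 11-fold lower number from compound 1 to compound 2 (1.05 log units; beyond the scatter), separates it from compound 1. Compound 3, `CC(C)N1CCN(c2cccc3c2C[C@H](CN(C)[C@H]2CCCc4cccnc42)NC3)CC1`, differs from compound 2 by 4-isopropylpiperazin-1-yl in place of 3,3-dimethylpiperazin-1-yl on an aromatic carbon. Among the measured compounds shown here, the one step that bears on this position, an 11-fold lower number from compound 1 to compound 2 (1.05 log units; beyond the scatter), was large, but it swapped a different pair of piperazines, so its direction cannot be carried over. The expectation is a moderate step, a 2.9-fold higher number from compound 2 to compound 3 (0.47 log units; beyond the scatter), toward a higher number. Compound 3 is therefore estimated at 100 nM, between 30 nM and 350 nM.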

Compound 3, half-maximal inhibitory concentration: 16.9 nM
Beside the measured number, compound 3's estimate is 5.9-fold (0.77 log units) above it; the whole stated range lies above it.
By their numbers in this assay, from the lowest: compounds 3 and 2 (each within the scatter of the next); then compound 1.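

In this assay, 4-isopropylpiperazin-1-yl in place of 3,3-dimethylpiperazin-1-yl gives a 2.0-fold lower number from compound 2 to compound 3 (0.30 log units; within the scatter) so these two piperazines are not separated, even with the hydrogen-bond donor count going from 1 to 0. On the ring amine nitrogen, isopropyl in place of oxetan-3-yl gives a 23-fold lower number from compound 1 to compound 3 (1.35 log units; beyond the scatter) so a substituent at that nitrogen is compatible with the lower numbers, and the higher number goes with oxetan-3-yl in this pair. No available evidence accounts for either step. Still open, as far as these compounds go, is how an unsubstituted piperazine amine, a longer alkyl chain or a carboxylic acid on that nitrogen would compare with compound 2 and compound 3.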